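A few compounds are considered here, and "the series" means these few. Any claim that something is new, unique, unknown or untested is made for them only; others in the source may bear on it.

Series notes, cytotoxicity on a leukemia line.

Compound 1 `CCN/C(SC)=C(/C#N)C(=O)Nc1ccc(OCC)cc1` is the open-chain member of the set, with compound 2 `C=CCN/C(SC)=C(/C#N)C(=O)Nc1ccc(OCC)cc1` as its close analog. Going by the values given here, the shared core of these two carries an ethylamino or an allylamino group; the difference between them, (vinyl in place of methyl on a saturated chain carbon bound to an amine nitrogen), is the only change. In a functional assay on CCRF-CEM cells (Homo sapiens) for cytotoxicity, read by resazurin assay, with a stated time of 48 h (on this read-out lower numbers stand for stronger inhibition and higher numbers for weaker inhibition), compound 1 gives 9890 nM, and compound 2 gives 18500 nM. That step, a 1.9-fold higher number from compound 1 to compound 2 (0.27 log units; within the scatter), is small and does not stand out from repeat-to-repeat noise.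

Compound 3 `CCNc1[nH]nc2nnn(-c3ccc(OCC)cc3)c(=O)c12` has a different, fused core; the difference between the two cores is not broken down here. In this assay compound 3 gives 15200 nM, a number that sits close to those of compound 1 and compound 2 and cannot be ordered against them.

Compound 4 `C=CCNc1[nH]nc2nnn(-c3ccc(OCC)cc3)c(=O)c12` has not yet been measured. It relates to compound 3 as compound 2 relates to compound 1: the change is vinyl in place of methyl on a saturated chain carbon bound to a nitrogen on an aromatic ring. Among the compounds with values here, it is the same kind of change as the one from compound 1 to compound 2, not the same, since the place differs: in the open-chain pair the carbon is bound to an amine nitrogen, in the fused pair to a nitrogen on an aromatic ring.

Within the data shown here, for compound 4 the step from compound 3 is expected to be a 1.4-fold higher number from compound 3 to compound 4 (0.16 log units; within the scatter), small and within scatter, because the one precedent, a 1.9-fold higher number from compound 1 to compound 2 (0.27 log units; within the scatter), was itself small. Compound 4 is therefore estimated at 22000 nM, with a plausible range of 9000 nM to 55000 nM.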

Compound 4, half-maximal inhibitory concentration: 4730 nM
The estimate for compound 4 lay 4.7-fold (0.67 log units) above the measured number; measured number below the stated range.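

On the fused core, vinyl in place of methyl gives a 3.2-fold lower number from compound 3 to compound 4 (0.51 log units; beyond the scatter), and this step clears the scatter. Set beside the open-chain pair in this assay, the same change does not carry over as a fixed shift, and the two steps differ: the same change on two cores in this assay, a 1.9-fold higher number (0.27 log units; within the scatter) from compound 1 to compound 2 and a 3.2-fold lower number (0.51 log units; beyond the scatter) from compound 3 to compound 4, 6.0-fold (0.78 log units) apart, beyond the scatter of two such steps This shows that, for these two pairs, the outcome of going from ethylamino to allylamino depends on the core; it does not show why, it rests on a single pair for each core, and it gives no rule for any other core.

Left open is whether the lower number on the fused core is particular to the allyl group or would also appear with a longer chain, such as butyl, or with a cyclopropylmethyl group on the same nitrogen. Also open, from the compounds shown here alone, is whether the difference between the two cores would persist with an amine or a carboxylic acid in place of the ethoxy group.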